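The source may report more compounds than this note shows. Statements on the series, on what has been measured and on what is new or still open speak of the compounds shown alone.

Values measured in an ADME assay on HMEC-1 cells (Homo sapiens) for antiproliferative activity, read by cell counting, with a stated time of 4 days; on this read-out lower numbers stand for stronger inhibition and higher numbers for weaker inhibition:
- compound 1 `C#C[C@@]1(O)[C@@H](CO)O[C@@H](n2cc(F)c3c(N)ncnc32)[C@@H]1O`: 61 nM
- compound 2 `C#C[C@@]1(O)[C@@H](CO)O[C@@H](n2cc(Br)c3c(N)ncnc32)[C@@H]1O`: 4.5 nM
- compound 3 `C#C[C@@]1(O)[C@@H](CO)O[C@@H](n2cc(I)c3c(N)ncnc32)[C@@H]1O`: not yet measured

Going by the values given here, compound 2 holds the lower of the two numbers in this assay, at 4.5 nM, and its only neighbour, compound 1, stands at 61 nM. The next change gives compound 3: iodo in place of bromo on an aromatic carbon. In words, this is iodo in place of bromo on an aromatic carbon.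

Among the compounds with values here, one measured step bears on this change: a 14-fold lower number from compound 1 to compound 2 (1.13 log units; beyond the scatter). That large step, beyond the scatter, was bromo in place of fluoro on the same carbon. Within the data shown here, it points towards a lower number for the next halogen, but a single step does not establish a trend, and no measured pair yet tests iodo. A further drop is therefore expected to be much smaller, and it may not clear the scatter. The estimated change is a 1.3-fold lower number from compound 2 to compound 3 (0.11 log units; within the scatter), a modest move to a lower number at most. For compound 3 the expected value is 3.5 nM, with an estimated range of 1 nM to 12 nM.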

Compound 3, half-maximal inhibitory concentration: 18 nM
Beside the measured number, compound 3's estimate is 5.1-fold (0.71 log units) below it; the measured number lies above the stated range.
By their numbers in this assay, from the lowest: compound 2; then compound 3; then compound 1.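

In this assay, the halogen on this aromatic carbon does not drive the number in one steady direction: a 4.0-fold higher number from compound 2 to compound 3 (0.60 log units; beyond the scatter), which turns back against the drop seen on going from fluoro to bromo. Two compounds could not show this turn. Iodo still keeps part of the gain over fluoro, with a 3.4-fold lower number from compound 1 to compound 3 (0.53 log units; beyond the scatter), so the series does not return to its starting point. Both steps lie beyond the scatter, which places compound 2, with bromo, lowest of the three, followed by compound 3 and then compound 1.

No measurement at hand accounts for this turn between bromo and iodo. It remains open where chloro on the same carbon would fall among these three halogens, and whether a group outside the halogens, such as methyl, nitrile or an amine, could match or go below the number of compound 2 at this position.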